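A few compounds are considered here, and "the series" means these few. Any claim that something is new, unique, unknown or untested is made for them only; others in the source may bear on it.

Two compounds of the series have been run in an ADME assay on microsomes from liver (Homo sapiens) for metabolic stability, read by LC-MS, using NADPH, with a stated time of 30 min, tested at 1 uM; on this read-out higher numbers stand for a more stable compound and lower numbers for a less stable compound. Compound 1 `C=CC(=O)Nc1cc(Nc2ncc(F)c(Nc3ccccc3S(=O)(=O)N(C)C)n2)c(OC)cc1N(C)CCN(C)C` gives 9% in this assay. Compound 2 `C=CC(=O)Nc1cc(Nc2ncc(I)c(Nc3ccccc3S(=O)(=O)C(C)C)n2)c(OC)cc1N(C)CCN(C)C` gives 14% in this assay. Compound 2 holds the higher of the two numbers, with compound 1 as its nearest neighbour, and the gap between them lies within the scatter, so the two values read as indistinguishable. Within the data shown here, the two compounds differ in more than one place and no single step between them is worked out; only the two values themselves stand.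

The next compound, compound 3 `C=CC(=O)Nc1cc(Nc2ncc(I)c(Nc3ccccc3S(=O)(=O)N(C)C)n2)c(OC)cc1N(C)CCN(C)C`, is reached from compound 2 by a single change: dimethylamino in place of isopropyl on a sulfonyl sulfur. Compound 1 already carries the dimethylsulfamoyl group on the shared core, with fluorine where compound 2 and compound 3 carry iodine, and compound 1 and compound 2 sit within the scatter of each other. On that basis no step beyond the scatter is expected in this assay. The expected step is small, as a number 3 percentage points lower from compound 2 to compound 3 (within the scatter). Compound 3 is estimated at 11% in this assay, with a range from 4% to 20%.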

Compound 3, percent of the compound remaining: 13%
For compound 3 the middle estimate is 2 percentage points below the measured one; the range from low to high includes it.
By their numbers in this assay, from the lowest: compounds 1, 3 and 2 (each within the scatter of the next).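

In this assay the replacement of isopropyl by dimethylamino on a sulfonyl sulfur can now be read on its own with iodo held fixed, as a number 1 percentage points lower from compound 2 to compound 3 (within the scatter) and so the two groups cannot be told apart at this place on the iodo compounds. Compound 3 also opens a second single-place comparison, with the dimethylsulfamoyl group held fixed: iodo in place of fluoro on an aromatic carbon reads as a number 4 percentage points higher from compound 1 to compound 3 (within the scatter) and so these two halogens cannot be told apart on this read-out either. No measurement at hand bears on why these readings sit as they do.

Still open, as far as these compounds go, is whether a larger group on the sulfonyl sulfur, such as a morpholine amide or a longer alkyl chain, or a chloro or nitrile group on that aromatic carbon, would give a step beyond the scatter in this assay. Also open, from the compounds shown here alone, is whether either replacement would read the same way on a compound that differs elsewhere on the shared core, since both readings rest on these three compounds alone.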